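This account rests on a few compounds, and the source may have more. Where it says the series, first, only, none or still open, it means among the compounds named here.

Measured compounds in the series:

Compound 1, `CC(c1ccc(OCc2c(-c3c(Cl)cccc3Cl)noc2C2CC2)nc1C(F)(F)F)N(C)c1ccc(C(=O)O)cc1`: 102%
Compound 2, `O=C(O)c1ccc(OCc2ccc(OCc3c(-c4c(Cl)cccc4Cl)noc3C3CC3)nc2C(F)(F)F)cc1`: 86%

In an assay on isolated protein for agonist activity at Bile acid receptor (Homo sapiens), read by FRET (on this read-out higher numbers stand for larger maximal responses and lower numbers for smaller maximal responses), compound 1 gives 102%. In this assay compound 2 gives 86%. Compound 2 stands lowest of the two numbers available; its nearest neighbour is compound 1, whose number lies higher by a margin beyond the usual scatter. Within the data shown here, no pair of measured compounds differs in a single place, so the gap between compound 1 and compound 2 can only be taken as the two values show it, without attribution to any one change.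

Compound 3, `CC(Oc1ccc(C(=O)O)cc1)c1ccc(OCc2c(-c3c(Cl)cccc3Cl)noc2C2CC2)nc1C(F)(F)F`, is still to be measured in this assay. Against compound 2 the structure shows (methyl in place of hydrogen on a saturated chain carbon bound to an aromatic carbon and an oxygen on an aromatic ring). Among the measured compounds shown here, compound 1 also carries a methyl on a saturated chain carbon, but the rest of its linker differs from both compound 2 and compound 3, so it gives no matching step. The expected step from compound 2 to compound 3 is small, a number 6 percentage points higher from compound 2 to compound 3 (within the scatter), none beyond the scatter in this assay. Compound 3 is estimated at 92%, with a range from 75% to 108%.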

Compound 3, largest response reached (reported as efficacy), in percent of the reference or control that the assay uses: 89%
Estimate against measurement, compound 3: 3 percentage points above; the range from low to high includes it.
By their numbers in this assay, from the lowest: compounds 2 and 3 (each within the scatter of the next); then compound 1.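

In this assay, methyl in place of hydrogen on a saturated chain carbon bound to an aromatic carbon and an oxygen on an aromatic ring gives a number 3 percentage points higher from compound 2 to compound 3 (within the scatter), so the change from (4-carboxyphenoxy)methyl to 1-(4-carboxyphenoxy)ethyl leaves the maximal response unresolved from that of compound 2. With the methyl present in both compounds, 4-carboxyphenoxy in place of (4-carboxyphenyl)(methyl)amino on a saturated chain carbon gives a number 13 percentage points lower from compound 1 to compound 3 (beyond the scatter), which turns the gap seen earlier only between compounds differing in more than one place into a single-change comparison, and of the two single changes now available only this one lies beyond the scatter. No measured evidence on either change accompanies these numbers, so the size of each step stands without explanation.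

Still open, going by these compounds, is whether an ethyl group or a longer chain on this saturated chain carbon would stay level with the methyl in this read-out. Also open, on these data alone, is whether the step between the oxygen and nitrogen links would hold with an amine hydrogen in place of the methyl on that nitrogen, or with hydrogen in place of the methyl on the chain carbon.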